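Amino for Fluoro on the Phenol Ring

The compounds below may be only part of what the source reports. "The series", "measured", "known", "first", "only" and "open" are said of these compounds alone.

Among the compounds with values here, compound 3 `C/C(=N\NC(=O)c1cccc(S(=O)(=O)N2CCOCC2)c1)c1cc(F)ccc1O` holds the lowest number among the compounds measured so far. In a functional assay on SMMC-7721 cells (Homo sapiens) for antiproliferative activity, read by MTT assay, with a stated time of 72 h (on this read-out lower numbers stand for stronger inhibition and higher numbers for weaker inhibition), compound 3 gives 1150 nM. Compound 1 `C/C(=N\NC(=O)c1cccc(S(=O)(=O)N2CCOCC2)c1)c1ccc(O)cc1` gives 88500 nM in this assay. Compound 2 `C/C(=N\NC(=O)c1cccc(S(=O)(=O)N2CCOCC2)c1)c1cc(O)ccc1O` reaches only the limit of > 100000 nM in this assay, so no number is known for it (the limit of > 100000 nM in this assay, at which 1 of the 3 values shown sits).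

Compound 4 `C/C(=N\NC(=O)c1cccc(S(=O)(=O)N2CCOCC2)c1)c1cccc(N)c1O` has not been measured. It differs from compound 3 in one place: 3-amino-2-hydroxyphenyl in place of 5-fluoro-2-hydroxyphenyl on a carbon with a double bond to nitrogen. The step that bears most directly on this change is an at least 86-fold lower number from compound 2 to compound 3 (1.93 log units; beyond the scatter), where a fluoro on the ring replaced a hydroxy; the step of a 77-fold lower number from compound 1 to compound 3 (1.89 log units; beyond the scatter) points the same way. Compound 4 gives up the fluoro that marked those large gains and brings in an amino instead, so the number is expected to rise again toward the weak values seen for compounds 1 and 2. For compound 4 the expected step is a 17-fold higher number from compound 3 to compound 4 (1.24 log units; beyond the scatter). Compound 4 is therefore estimated at 20000 nM, with a range from 3000 nM to 100000 nM.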

Compound 4, half-maximal inhibitory concentration: 2330 nM
Compound 4: middle estimate off by 8.6-fold (0.93 log units), on the high side; measured number below the stated range.
By their numbers in this assay, from the lowest: compound 3; then compound 4; then compound 1. At a limit, above all of these: compound 2.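

In this assay, within the data shown here, the fluoro is not the only group that goes with a low number: putting 3-amino-2-hydroxyphenyl in place of 5-fluoro-2-hydroxyphenyl gives only a 2.0-fold higher number from compound 3 to compound 4 (0.31 log units; beyond the scatter) on the scale of this series. The amino compound also keeps most of the large gain over the two other phenols, with a 38-fold lower number from compound 1 to compound 4 (1.58 log units; beyond the scatter) and an at least 42-fold lower number from compound 2 to compound 4 (1.63 log units; beyond the scatter) in the same read-out. The second of these steps is only a floor, and compound 2 has a limit rather than a number: the limit of > 100000 nM in this assay, at which 1 of the 4 values shown sits.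

The compounds shown leave open whether a chloro or a methoxy on the phenol ring would also keep the number low. Also open, as far as these compounds go, is whether the number would hold with a dimethylamino or an acetamide group in place of the amino group.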